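Trimming the lactone: phenyl gives way to methyl

The source may hold more compounds than are shown below. What is called first, only, known or untested is meant among the compounds shown, and "the series" means these compounds.

compound 1, `C=C(Br)C(=O)Nc1ccc2oc(C(=O)NCCNC(=O)c3cc(OCC4(c5ccc(Cl)cc5)CC(=C)C(=O)O4)nn3C)cc2c1`: 550 nM
compound 2, `C=C(Br)C(=O)Nc1ccc2sc(C(=O)NCCNC(=O)c3cc(OCC4(c5ccc(Cl)cc5)CC(=C)C(=O)O4)nn3C)cc2c1`: 260 nM
compound 3, `C=C1CC(COc2cc(C(=O)O)n(C)n2)(c2ccccc2)OC1=O`: > 10000 nM

In a functional assay on L1210 cells (Mus musculus) for antiproliferative activity (on this read-out lower numbers stand for stronger inhibition and higher numbers for weaker inhibition), compound 1 gives 550 nM and compound 2 gives 260 nM. For compound 3 the read-out is only a limit, > 10000 nM. Compound 3 therefore stands at the limit of > 10000 nM in this assay, at which 1 of the 3 values shown sits, with no number of its own among the three values shown. Compound 4, `C=C1CC(C)(COc2cc(C(=O)O)n(C)n2)OC1=O`, differs from compound 3 by methyl in place of phenyl on a saturated ring carbon. Going by the values given here, no measured step between two compounds exists here, so the change has no precedent to lean on. Since compound 3 already sits at the limit, compound 4 is expected to remain there, and no step beyond the scatter is expected. The estimate for compound 4 is 20000 nM, ranging from 6000 nM to 100000 nM. The expected step is a step that the limit leaves unreadable from compound 3 to compound 4.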

Compound 4, half-maximal inhibitory concentration: > 10000 nM
Compound 4: only a limit was reported; the forecaster's own chance of this, stated with the estimate: 85%; the middle value lies beyond the limit too.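

Going by these compounds alone, no step from compound 3 to compound 4 can be read in this assay, because both results are limits and not numbers: the limit of > 10000 nM in this assay, at which 2 of the 4 values shown sit. The compounds shown leave open how methyl in place of phenyl changes activity.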